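Aryl sulfonamide series: phenyl replacing tert-butyl on benzylamine

The source may hold more compounds than are shown below. What is called first, only, known or untested is meant among the compounds shown, and "the series" means these compounds.

Measured:
compound 1 `CC(C)(C)c1ccc(CNCCNS(=O)(=O)c2cc(C(F)(F)F)cc(C(F)(F)F)c2)cc1` — 14000 nM
compound 2 `O=S(=O)(NCCCCNCc1ccc(Br)cc1)c1cc(C(F)(F)F)cc(C(F)(F)F)c1` — 1600 nM
compound 3 `O=S(=O)(NCCCNCc1ccc(Cl)cc1)c1cc(C(F)(F)F)cc(C(F)(F)F)c1` — 2800 nM

In a functional assay on HT-29 cells (Homo sapiens) for inhibition, read by MTT assay, with a stated time of 72 h (a higher number here means a weaker inhibitor of growth, a lower number a stronger inhibitor of growth), compound 1 stands highest of the three, beyond the scatter from both compound 2 and compound 3. The only shown step, a 1.8-fold higher number from compound 2 to compound 3 (0.24 log units; within the scatter), concerns the chain and halogen and does not touch the change to compound 4 `O=S(=O)(NCCNCc1ccc(-c2ccccc2)cc1)c1cc(C(F)(F)F)cc(C(F)(F)F)c1`: phenyl in place of tert-butyl on an aromatic carbon. Among the compounds with values here, no measured step bears on it. Compounds 2 and 3 carry other groups on that aromatic carbon and sit lower than compound 1, while differing in chain as well. The expectation for compound 4 is therefore a modest lowering, a 2.8-fold lower number from compound 1 to compound 4 (0.45 log units; beyond the scatter), with wide uncertainty. Compound 4 is estimated at 5000 nM (range 1500 nM to 16000 nM).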

Compound 4, concentration for 50% growth inhibition: 2700 nM
Compound 4: middle estimate off by 1.9-fold (0.27 log units), on the high side; low and high end bracket the measured number.
By their numbers in this assay, from the lowest: compounds 2, 4 and 3 (each within the scatter of the next); then compound 1.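

In this assay, within the data shown here, phenyl in place of tert-butyl on an aromatic carbon, para to a large group, gives a 5.2-fold lower number from compound 1 to compound 4 (0.71 log units; beyond the scatter) and is the first direct reading of this position. The rest of compound 1 stays unchanged, so this step belongs to the exchange at this carbon alone. Nothing available explains the size of the step.

Still open, on these data alone, is how a methoxy group or a pyridine ring would read at this carbon. Also open, as far as these compounds go, is whether the phenyl step would hold on a longer chain.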